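Amide aryl change from compound 3 to compound 4

A few compounds are considered here, and "the series" means these few. Any claim that something is new, unique, unknown or untested is made for them only; others in the source may bear on it.

In an ADME assay on MT4 cells (Homo sapiens) for cytotoxicity, read by MTT assay, with a stated time of 5 days (a higher number here means that more compound is tolerated, a lower number that less compound is tolerated), compound 3 (`COc1cc2nc([S+]([O-])CC(=O)Nc3cccc(C(F)(F)F)c3)nc(Nc3c(Cl)cc(/C=C/C#N)cc3Cl)c2cc1OC`) gives 21800 nM, the lower of the two actual numbers in the set. Compound 1 (`COc1cc2nc([S+]([O-])CC(=O)Nc3ccc([N+](=O)[O-])cc3)nc(Nc3c(Cl)cc(/C=C/C#N)cc3Cl)c2cc1OC`) gives 92800 nM. Compound 2 (`COc1cc2nc([S+]([O-])CC(=O)Nc3ccccc3F)nc(Nc3c(Cl)cc(/C=C/C#N)cc3Cl)c2cc1OC`) gives > 208000 nM, which is a limit of the assay and not a number.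

Compound 4 (`COc1cc2nc([S+]([O-])CC(=O)Nc3ccccc3C#N)nc(Nc3c(Cl)cc(/C=C/C#N)cc3Cl)c2cc1OC`) carries 2-cyanophenyl in place of 3-(trifluoromethyl)phenyl on an amide-type nitrogen.

Two measured steps introduce the 3-(trifluoromethyl)phenyl group that compound 4 gives up: a 4.3-fold lower number from compound 1 to compound 3 (0.63 log units; beyond the scatter) and an at least 9.5-fold lower number from compound 2 to compound 3 (0.97 log units; beyond the scatter). Both lie beyond the scatter and both run downward. The 2-fluorophenyl group of compound 2 also compares well with the group of compound 1, as shown by an at least 2.2-fold higher number from compound 1 to compound 2 (0.35 log units; beyond the scatter). Leaving the 3-(trifluoromethyl)phenyl group is therefore expected to give a modest rise in this assay, not a change within the scatter.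

The estimated step is a 3.9-fold higher number from compound 3 to compound 4 (0.59 log units; beyond the scatter). Compound 4 is expected at 85000 nM, with an estimated range of 28000 nM to 210000 nM.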

Compound 4, half-maximal cytotoxic concentration: > 206000 nM
Compound 4: only a limit was reported (the forecaster's own chance of this, stated with the estimate: 30%); middle value at least 2.4-fold (0.38 log units) from the limit.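

Replacing 3-(trifluoromethyl)phenyl with 2-cyanophenyl on the amide-type nitrogen gives an at least 9.4-fold higher number from compound 3 to compound 4 (0.97 log units; beyond the scatter) in this assay, so compound 4 joins compound 2 as a second compound that stands clear of compound 3. The same group gives an at least 2.2-fold higher number from compound 1 to compound 4 (0.34 log units; beyond the scatter), which places 2-cyanophenyl above the 4-nitrophenyl group as well. Compound 4 is recorded only as a limit of the assay, not a number: the limit of > 206000 nM in this assay, at which 1 of the 4 values shown sits.

From the compounds shown here alone, compound 2 is also recorded only as a limit, so the step that swaps fluoro for cyano on the aromatic carbon cannot be read: the limit of > 208000 nM in this assay, at which 1 of the 4 values shown sits. How far either compound lies beyond its limit stays open, as does how a phenyl ring carrying an amine or a carboxylic acid on this amide-type nitrogen would read in this assay.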